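The source may report more compounds than this note shows. Statements on the series, on what has been measured and on what is new or still open speak of the compounds shown alone.

Of the compounds shown here, three of one shared core have been measured in an assay on isolated protein for displacement of a labelled ligand from metabotropic glutamate receptor 5 (Homo sapiens), with a stated time of 60 min, tested at 1 uM; a higher number here means more inhibition at the concentration tested (going by the name of the read-out), a lower number less inhibition. Compound 1 `Cc1ccc2ncc(S(=O)(=O)c3ccc(F)cc3)c(N3CCC(C)CC3)c2c1` gives 90% in this assay, compound 2 `Cc1ccc2ncc(S(=O)(=O)c3ccc(Cl)c(Cl)c3)c(N3CCC(C)CC3)c2c1` gives 82%, and compound 3 `Cc1ccc2ncc(S(=O)(=O)c3ccc(C)c(C)c3)c(N3CCC(C)CC3)c2c1` gives 90%. Compound 3 thus stands level with compound 1, the two together at the top of the three values; one step is a number 8 percentage points higher from compound 2 to compound 3 (within the scatter), and both a number 8 percentage points lower from compound 1 to compound 2 (within the scatter) and no change at the digits printed from compound 1 to compound 3 (within the scatter) lie within the scatter, so the three aryl groups on the sulfonyl sulfur are not told apart here. Compound 4 `Cc1ccc2ncc(S(=O)(=O)c3ccc(Cl)cc3)c(N3CCC(C)CC3)c2c1` is the next change: 4-chlorophenyl in place of 3,4-dimethylphenyl on a sulfonyl sulfur. Going by the values given here, because a number 8 percentage points lower from compound 1 to compound 2 (within the scatter) and every other step so far stayed within the scatter, compound 4 is expected to give 87%, between 78% and 94%. The expected step is a number 3 percentage points lower from compound 3 to compound 4 (within the scatter), none beyond the scatter.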

Compound 4, a percentage reported as inhibition, at one concentration (the size of the read-out at that concentration, not a potency): 79%
The estimate for compound 4 lay 8 percentage points above the measured number; low and high end bracket the measured number.
By their numbers in this assay, from the lowest: compounds 4, 2, 1 and 3 (each within the scatter of the next, the first and the last beyond it).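

Going by these compounds alone, compound 4 gives the first steps at this position on a sulfonyl sulfur that lie beyond the scatter: 4-chlorophenyl in place of 3,4-dimethylphenyl gives a number 11 percentage points lower from compound 3 to compound 4 (beyond the scatter) in this assay. A single atom is enough for a step of the same size, since chloro in place of fluoro on an aromatic carbon gives a number 11 percentage points lower from compound 1 to compound 4 (beyond the scatter), whereas hydrogen in place of chloro gives a number 3 percentage points lower from compound 2 to compound 4 (within the scatter). No measurement here explains these differences. Still open, going by these compounds, is how a group such as an amine, a carboxylic acid or a methoxy group would read on the aryl ring.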